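This account rests on a few compounds, and the source may have more. Where it says the series, first, only, none or still open, it means among the compounds named here.

Two measured members of the series are on hand. Compound 1 `C=C1CC[C@@H]2[C@](C)(CO)[C@H](O)CC[C@@]2(C)[C@@H]1CC(Sc1ccccn1)C1=CCOC1=O` gives 18000 nM in a functional assay on PC-3 cells (Homo sapiens) for inhibition, read by MTT assay, with a stated time of 48 h; on this read-out higher numbers stand for weaker inhibition and lower numbers for stronger inhibition. Compound 2 `C=C1CC[C@@H]2[C@](C)(CO)[C@H](O)CC[C@@]2(C)[C@@H]1C/C=C1/C(=O)OC[C@H]1OC(=O)CSc1ccc(C)cc1` gives 27000 nM in this assay, which is the highest of the two numbers; the nearest is compound 1, and the gap between the two values lies within the usual scatter, so no order between them is claimed. Compound 3 `C=C1CC[C@@H]2[C@](C)(CO)[C@H](O)CC[C@@]2(C)[C@@H]1C/C=C1/C(=O)OC[C@H]1OC(=O)CCCSc1ccc(C)cc1` is not yet measured in this assay. Compound 3 differs from compound 2 by 2-((4-methylphenyl)sulfanyl)ethyl in place of (4-methylphenyl)sulfanyl on a saturated chain carbon bound to a carbonyl carbon. Among the measured compounds shown here, no step between measured compounds of this kind is available, so the expectation rests on the position of compound 2 alone, the change being the same (4-methylphenyl)sulfanyl group set on a longer saturated chain. Compound 3 is expected to give roughly 25000 nM in this assay, within a range of 8000 nM to 80000 nM, and the expected step of a 1.1-fold lower number from compound 2 to compound 3 (0.03 log units; within the scatter) is none beyond the scatter in either direction.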

Compound 3, half-maximal inhibitory concentration: 16000 nM
Estimate against measurement, compound 3: 1.6-fold (0.19 log units) above, within the range that was stated.
By their numbers in this assay, from the lowest: compounds 3, 1 and 2 (each within the scatter of the next).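

In this assay the first pair differing in one place gives a 1.7-fold lower number from compound 2 to compound 3 (0.23 log units; within the scatter) and so shows no shift beyond the scatter when 2-((4-methylphenyl)sulfanyl)ethyl takes the place of (4-methylphenyl)sulfanyl on a saturated chain carbon bound to a carbonyl carbon. At this position, then, the same (4-methylphenyl)sulfanyl group on the longer chain leaves the read-out in the range of compound 2. Nothing measured here offers an explanation for this result.

Going by these compounds, a single step within the scatter cannot separate a flat response to chain length from a small real one, so the trend with chain length stays open. Also open, on these data alone, is how the read-out responds at this position to a longer chain still, or to an amine or a carboxylic acid in place of the (4-methylphenyl)sulfanyl group.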